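The source may hold more compounds than are shown below. What is called first, only, known or untested is meant among the compounds shown, and "the series" means these compounds.

- compound 1 `S=C(N/N=C/c1cccs1)Nc1ccc(Cl)cc1`: 7400 nM
- compound 2 `S=C(N/N=C/c1cccs1)Nc1cccc2ccccc12`: 15200 nM
- compound 3 `Cc1ccc(NC(=S)N/N=C/c2cccs2)cc1`: 19500 nM

In a functional assay on 786-0 cells (Homo sapiens) for inhibition, read by sulforhodamine B assay, with a stated time of 48 h (a higher number here means a weaker inhibitor of growth, a lower number a stronger inhibitor of growth), compound 1 gives the lowest of the three numbers, 7400 nM. Compound 4 `S=C(N/N=C/c1cccs1)Nc1ccc(Br)cc1` is the next case: bromo in place of chloro on an aromatic carbon, para to a large group. For the measured compounds named here, one measured step bears on this place: a 2.6-fold higher number from compound 1 to compound 3 (0.42 log units; beyond the scatter), with methyl in place of chloro, modest in size. Going by the values given here, no measured step has bromo entering, so direction remains open, and no step beyond the scatter is expected for this swap between halogens. The estimated step is a 1.1-fold higher number from compound 1 to compound 4 (0.03 log units; within the scatter). For compound 4, the expected value is 8000 nM, with an estimated range of 4000 nM to 16000 nM.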

Compound 4, concentration for 50% growth inhibition: 4500 nM
Compound 4: the middle estimate sits 1.8-fold (0.25 log units) above what was measured; the measured number falls inside the stated range.
By their numbers in this assay, from the lowest: compounds 4 and 1 (each within the scatter of the next); then compounds 2 and 3 (each within the scatter of the next).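

Bromo in place of chloro gives a 1.6-fold lower number from compound 1 to compound 4 (0.22 log units; within the scatter) in this assay, so the two halogens on this aromatic carbon are not separated. Bromo in place of methyl gives a 4.3-fold lower number from compound 3 to compound 4 (0.64 log units; beyond the scatter), which places compound 3 apart from both halogen compounds at this position. Nothing on hand accounts for this gap.

Going by these compounds, whether fluoro, methoxy, an amine or a carboxylic acid on this carbon would stay with the halogens or with methyl remains open. Also open, on these data alone, is whether the gap between bromo and methyl holds on a different core.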